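The source may report more compounds than this note shows. Statements on the series, on what has been measured and on what is new or still open speak of the compounds shown alone.

Measured compounds, with apparent permeability in an ADME assay for permeability, using PAMPA, with a stated time of 4 h, at pH 5.5; a lower number here means that the compound crosses the layer more slowly, a higher number that the compound crosses the layer faster:
compound 1 `NCCCCN(C[C@@H]1Cc2ncccc2CN1)[C@H]1CCCc2cccnc21` gives 2 nm/s;
compound 2 `NCCCCN(C[C@@H]1Cc2nccnc2CN1)[C@H]1CCCc2cccnc21` gives 2 nm/s;
compound 3 `NC(=O)NCCCCN(C[C@H]1Cc2ncccc2CN1)[C@H]1CCCc2cccnc21` gives 7 nm/s.

Compound 3 stands highest of the three numbers in this assay; the gap to compound 1 and the equal gap to compound 2 both lie beyond the usual scatter. Compounds 1 and 2 sit together within the scatter, so no order is read between them.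

Compound 4 `c1cnc2c(c1)CN[C@@H](CN(CCCC1CCNCC1)[C@H]1CCCc3cccnc31)C2` is not yet measured. Relative to compound 3 the change is piperidin-4-yl in place of ureidomethyl on a saturated chain carbon, three bonds along the chain from an amine nitrogen. The urea of compound 3 is thus gone, and a ring nitrogen with one donor takes its place on the chain.

Among the compounds with values here, neither compound 1 nor compound 2 carries a urea; in this assay compound 1 gives 2 nm/s and compound 2 gives 2 nm/s; the only compound with the urea, compound 3, gives 7 nm/s. On that basis the step of a 2.8-fold lower number from compound 3 to compound 4 (0.45 log units; beyond the scatter) is expected to be downward and beyond the scatter. The estimate for compound 4 in this assay is 2.5 nm/s, expected to fall between 1 nm/s and 7 nm/s.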

Compound 4, apparent permeability: 14 nm/s
Compound 4: the middle estimate sits 5.6-fold (0.75 log units) below what was measured, and the stated range ends below it.
By their numbers in this assay, from the lowest: compounds 1 and 2 (each within the scatter of the next); then compounds 3 and 4 (each within the scatter of the next).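

In this assay, piperidin-4-yl in place of ureidomethyl on a saturated chain carbon, three bonds along the chain from an amine nitrogen, gives a 2.0-fold higher number from compound 3 to compound 4 (0.30 log units; within the scatter), so the two groups cannot be told apart at this position. The urea is therefore not needed here for a number of this size: compound 4 has no urea and gives 14 nm/s in this read-out. Nothing on hand explains why the two groups read alike.

Still open, from the compounds shown here alone, is whether the ring nitrogen of the piperidine matters, which a cyclohexyl group or a 1-methylpiperidin-4-yl group on the same chain would test. Also open, going by these compounds, is whether a carboxylic acid at the chain end would stay within the scatter of compound 4, and whether the same change reads alike on the core of compound 2.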